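Sulfonyl morpholine series: from compound 3 to compound 4

The compounds below may be only part of what the source reports. "The series", "measured", "known", "first", "only" and "open" are said of these compounds alone.

Measured so far in an ADME assay on WI-38 cells (Homo sapiens) for cytotoxicity, read by sulforhodamine B assay, with a stated time of 24 h; on this read-out lower numbers stand for stronger inhibition and higher numbers for weaker inhibition:
- compound 1 `Cc1ccc(/N=C2\C(=O)Nc3ccc(S(=O)(=O)N4CCOCC4)cc32)cc1` gives 309000 nM
- compound 2 `O=C1Nc2ccc(S(=O)(=O)N3CCOCC3)cc2/C1=N/c1cccc(C(F)(F)F)c1` gives 226000 nM
- compound 3 `N/N=C1\C(=O)Nc2ccc(S(=O)(=O)N3CCOCC3)cc21` gives 391000 nM

Compound 3 stands within the scatter of both other measured compounds, with a 1.3-fold higher number from compound 1 to compound 3 (0.10 log units; within the scatter) and a 1.7-fold higher number from compound 2 to compound 3 (0.24 log units; within the scatter). The next compound to be measured is compound 4 `CC(=O)c1cccc(/N=C2\C(=O)Nc3ccc(S(=O)(=O)N4CCOCC4)cc32)c1`, with 3-acetylphenyl in place of amino on a double-bonded nitrogen. This is a large change in counted atoms, and compound 4 carries a substituted phenyl on that nitrogen, as compound 1 and compound 2 do.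

The same two steps bear on this change, as they exchange a substituted phenyl and amino at that place, though they run in the opposite direction. The exchange of one substituted phenyl for another also bears on it, with a 1.4-fold lower number from compound 1 to compound 2 (0.14 log units; within the scatter). All three steps stay within the scatter, so no step beyond the scatter is expected in this assay. For the measured compounds named here, no 3-acetylphenyl compound has been measured yet, which leaves the estimate resting on these three compounds alone.

The expected change is a 1.4-fold lower number from compound 3 to compound 4 (0.16 log units; within the scatter). For compound 4 the estimated value is 270000 nM, with an expected range from 140000 nM to 480000 nM.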

Compound 4, half-maximal inhibitory concentration: 177000 nM
Beside the measured number, compound 4's estimate is 1.5-fold (0.18 log units) above it; measured number inside the range.
By their numbers in this assay, from the lowest: compounds 4, 2, 1 and 3 (each within the scatter of the next, the first and the last beyond it).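

In this assay, for the compounds shown here, there is a 2.2-fold lower number from compound 3 to compound 4 (0.34 log units; beyond the scatter), the first step beyond the scatter, so exchanging amino for 3-acetylphenyl on the double-bonded nitrogen can register a difference, though only a modest one. Compound 4 does not stand apart from the other substituted phenyl compounds, with a 1.3-fold lower number from compound 2 to compound 4 (0.11 log units; within the scatter) for acetyl in place of trifluoromethyl on an aromatic carbon and a 1.7-fold lower number from compound 1 to compound 4 (0.24 log units; within the scatter) for the exchange of one substituted phenyl for another. The separation therefore holds for compound 3 and compound 4 alone, as compound 1 and compound 2 remain within the scatter of compound 3 on the same kind of exchange, and nothing given here accounts for the step.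

From the compounds shown here alone, whether the acetyl group itself matters, or the small separation merely reflects where compound 4 falls among the substituted phenyl compounds, remains open. A carboxylic acid or an aminomethyl group on the phenyl, or a longer alkyl chain in its place on the double-bonded nitrogen, would test whether the numbers can move further from those of these four compounds.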